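Benzyl in Place of Isopropyl on the Five-Membered Ring

A few compounds are considered here, and "the series" means these few. Any claim that something is new, unique, unknown or untested is made for them only; others in the source may bear on it.

Compound 3 `CC(C)C1CC(=O)N(c2ccccc2C(=O)OCC2CCCN(CCCc3ccccc3)C2)C1=O` gives 2500 nM in a functional assay with Neuronal acetylcholine receptor; alpha3/beta4 (Homo sapiens) as the target (a lower number here means a stronger inhibitor, a higher number a weaker inhibitor), the second highest of the three numbers shown. Compound 1 `CC1C(=O)N(c2ccccc2C(=O)OCC2CCCN(CCCc3ccccc3)C2)C(=O)C1C` gives 6000 nM in this assay, and compound 2 `CCCCC1CC(=O)N(c2ccccc2C(=O)OCC2CCCN(CCCc3ccccc3)C2)C1=O` gives 1500 nM. The step of a 2.4-fold lower number from compound 1 to compound 3 (0.38 log units; beyond the scatter) is modest, while a 1.7-fold higher number from compound 2 to compound 3 (0.22 log units; within the scatter) stays within the scatter. Compound 4 `O=C(OCC1CCCN(CCCc2ccccc2)C1)c1ccccc1N1C(=O)CC(Cc2ccccc2)C1=O` differs from compound 3 by benzyl in place of isopropyl on a saturated ring carbon. Within the data shown here, the one measured change at this ring carbon, a 1.7-fold higher number from compound 2 to compound 3 (0.22 log units; within the scatter), swaps isopropyl for butyl and produces no clear movement, so a benzyl there offers little to go on. A step of modest size at most, in either direction, is expected in this assay. Compound 4 is therefore estimated at 1800 nM, within a range from 500 nM to 6000 nM. That estimate means a step of a 1.4-fold lower number from compound 3 to compound 4 (0.14 log units; within the scatter), expected to stay small.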

Compound 4, half-maximal inhibitory concentration: 1300 nM
Compound 4: middle estimate off by 1.4-fold (0.14 log units), on the high side; low and high end bracket the measured number.
By their numbers in this assay, from the lowest: compounds 4, 2 and 3 (each within the scatter of the next); then compound 1.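

In this assay, an aromatic ring at this saturated ring carbon brings no clear shift: a 1.9-fold lower number from compound 3 to compound 4 (0.28 log units; within the scatter) with benzyl in place of isopropyl, and a 1.2-fold lower number from compound 2 to compound 4 (0.06 log units; within the scatter) with phenyl in place of propyl on a saturated chain carbon bound to a saturated ring carbon. Isopropyl, butyl and benzyl at this carbon thus all lie within the scatter of one another. Nothing available gives a reason for this. Still open, going by these compounds, is whether an amine or a carboxylic acid at this carbon, or a chain longer than butyl, would keep the number in the same range.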